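Methoxy for Methyl in a Cytotoxicity Series

The source may report more compounds than this note shows. Statements on the series, on what has been measured and on what is new or still open speak of the compounds shown alone.

Of the compounds shown here, three sharing one core have been measured in a functional assay on C6 cells (Rattus norvegicus) for cytotoxicity, read by MTT assay, with a stated time of 24 h, tested at 100 ug/mL; on this read-out lower numbers stand for a stronger effect and higher numbers for a weaker effect at the one concentration tested. Compound 3 `Cc1ccc(-c2cs/c(=N/NC(=O)CSc3ncccn3)n2-c2ccccc2)cc1` gives 45.9%. Compound 2 `O=C(CSc1ncccn1)N/N=c1/scc(-c2ccc(Cl)cc2)n1-c1ccccc1` gives 45.5%, a value within the usual scatter of that of compound 3. Compound 1 `COc1ccc(-c2cs/c(=N/NC(=O)CSc3nnc(C)s3)n2-c2ccccc2)cc1` gives 25.9%, a number lower than that of compound 3 by more than the scatter allows; compound 1 also carries a different sulfur-linked heteroaryl, so its two values alone say nothing about one change.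

Compound 4 `COc1ccc(-c2cs/c(=N/NC(=O)CSc3ncccn3)n2-c2ccccc2)cc1` differs from compound 3 in one place: methoxy in place of methyl on an aromatic carbon. Going by the values given here, no measured step replaces methyl with methoxy. Among the compounds with values here, the only step on this ring, a number 0.4 percentage points higher from compound 2 to compound 3 (within the scatter), did not move the read-out beyond the scatter. Within the data shown here, no step connects compound 1 to compound 4 either. The expectation for compound 4 is therefore a number close to that of compound 3, with a wide range, a number 5.9 percentage points lower from compound 3 to compound 4 (within the scatter). Compound 4 is estimated to give 40%, between 24% and 54%.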

Compound 4, a percentage reported as activity, at one concentration (the size of the read-out at that concentration, not a potency): 51.5%
For compound 4 the middle estimate is 11.5 percentage points below the measured one; the measured number falls inside the stated range.
By their numbers in this assay, from the lowest: compound 1; then compounds 2, 3 and 4 (each within the scatter of the next).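

In this assay, the para position of the aromatic ring tolerates change: methoxy in place of methyl gives a number 5.6 percentage points higher from compound 3 to compound 4 (within the scatter), and methoxy in place of chloro gives a number 6 percentage points higher from compound 2 to compound 4 (within the scatter), so with pyrimidin-2-yl on the sulfur, these three groups cannot be told apart. Compound 4 also gives compound 1 a partner that differs in one place: with methoxy on the ring in both, pyrimidin-2-yl in place of 5-methyl-1,3,4-thiadiazol-2-yl gives a number 25.6 percentage points higher from compound 1 to compound 4 (beyond the scatter), so here the group on the sulfur moves the read-out beyond the scatter. Nothing available explains why these groups behave this way. From the compounds shown here alone, it remains open whether an amine or a carboxylic acid on the same ring carbon would also leave the read-out in place. Going by these compounds, it is equally open whether the 5-methyl-1,3,4-thiadiazol-2-yl group would have the same effect alongside methyl or chloro on the ring.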